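A few compounds are considered here, and "the series" means these few. Any claim that something is new, unique, unknown or untested is made for them only; others in the source may bear on it.

Three compounds share one core and were measured in an in vitro assay on BHK cells for displacement of a labelled ligand from Glucagon receptor (Homo sapiens), read by scintillation proximity assay; on this read-out lower numbers stand for stronger inhibition and higher numbers for weaker inhibition. Compound 1 `O=C(O)CCNC(=O)c1ccc(CC(c2ccc(OC(F)(F)F)cc2)c2nc(-c3ccc(Cl)cc3)cs2)cc1` gives 98 nM, compound 2 `O=C(O)CCNC(=O)c1ccc(CN(c2ccc(Cl)cc2)c2nc(-c3ccc(C(F)(F)F)cc3)cs2)cc1` gives 76 nM, and compound 3 `O=C(O)CCNC(=O)c1ccc(CN(c2ccc(C3=CCCCC3)cc2)c2nc(-c3ccc(Cl)cc3)c(-c3ccccc3)s2)cc1` gives 86 nM. Of these numbers compound 2 has the smallest, yet its gaps to compound 3 and to compound 1 both lie within the usual scatter, so the three cannot be told apart. Compound 4 `O=C(O)CCNC(=O)c1ccc(CN(c2ccc3c(c2)CCC3)c2nc(-c3ccc(C(F)(F)F)cc3)cs2)cc1` differs from compound 2 in one place: 2,3-dihydro-1H-inden-5-yl in place of 4-chlorophenyl on a nitrogen on an aromatic ring. Among the compounds with values here, no measured pair shows this kind of swap, and compound 3 carries a larger group at a similar spot while staying close to compound 2. The step from compound 2 to compound 4 in this assay is therefore expected to stay small, a 1.1-fold higher number from compound 2 to compound 4 (0.02 log units; within the scatter), with no clear direction. Compound 4 is expected to give about 80 nM, somewhere between 30 nM and 250 nM.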

Compound 4, half-maximal inhibitory concentration: 86 nM
Beside the measured number, compound 4's estimate is 1.1-fold (0.03 log units) below it, and the stated range covers the measured number.
By their numbers in this assay, from the lowest: compounds 2, 3, 4 and 1 (each within the scatter of the next).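

In this assay, putting 2,3-dihydro-1H-inden-5-yl in place of 4-chlorophenyl on the nitrogen gives a 1.1-fold higher number from compound 2 to compound 4 (0.05 log units; within the scatter). Within the data shown here, this is the first direct one-place comparison at this position: the chlorine can leave and a five-membered non-aromatic carbon ring can enter without a change this read-out can separate. Nothing available here bears on why the step is so small. Going by these compounds, both groups are carbon-based rings with no hydrogen-bond donors or acceptors, so it remains open whether a pyridine ring or a ring carrying a hydroxyl group would be tolerated equally at this place.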